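A few compounds are considered here, and "the series" means these few. Any claim that something is new, unique, unknown or untested is made for them only; others in the source may bear on it.

Measured to date in a functional assay on cells for positive allosteric modulation of G-protein coupled receptor 68 (Homo sapiens), read by a luciferase reporter and cAMP accumulation, with a stated time of 30 min, at pH 6.8 and pH 8.3, in the presence of a further agent that is not named here; a lower number here means a less potent compound, a higher number a more potent compound, by a factor of ten per unit of this negative logarithm:
Compound 1 `Nc1nc(NCc2ccccc2)nc(-c2ccccc2CO)n1`: 4.35
Compound 2 `CC(C)Oc1ccc(-c2nc(N)nc(NCc3ccccc3)n2)c(CO)c1`: 4.91

For the measured compounds named here, compound 1 holds the lower of the two numbers in this assay; the only measured step from it, a number 0.56 log units higher from compound 1 to compound 2 (beyond the scatter), is modest and beyond the scatter, with isopropoxy entering on an aromatic carbon of the ring that carries the hydroxymethyl group.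

Compound 3 `CC(C)Oc1ccc(CNc2nc(N)nc(-c3ccccc3CO)n2)cc1` is not yet measured. Relative to compound 1 the change is isopropoxy in place of hydrogen on an aromatic carbon. The same group enters, but on the other six-membered carbon ring, so the measured step bears on it only by analogy of the entering group, not of its place. Going by the values given here, no measured pair tells what an isopropoxy on that ring does.

The step to compound 3 is therefore expected to be small and uncertain in sign, a number 0.25 log units higher from compound 1 to compound 3 (within the scatter), leaning to a gain by analogy with the step from compound 1 to compound 2. Compound 3 is estimated at 4.6 in this assay, within 3.9 to 5.3.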

Compound 3, negative logarithm of the antagonist equilibrium constant: 4.99
Compound 3: the middle estimate sits 0.39 log units below what was measured; measured number inside the range.
By their numbers in this assay, from the lowest: compound 1; then compounds 2 and 3 (each within the scatter of the next).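

In this assay, isopropoxy on an aromatic carbon of the ring without the hydroxymethyl group, para to a large group, gives a number 0.64 log units higher from compound 1 to compound 3 (beyond the scatter) and so shows directly that this position responds to the change. For the compounds shown here, until now the only isopropoxy step lay on the ring carrying the hydroxymethyl group; read together with a number 0.56 log units higher from compound 1 to compound 2 (beyond the scatter) and measured from the same parent, the same group now gives a step beyond the scatter on either ring of compound 1. No measurement on hand explains this gain.

Going by these compounds, whether isopropoxy on both rings of one compound adds to these steps remains open. Also open, on these data alone, is how this position responds to other groups, such as methoxy, an amine or a carboxylic acid.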